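Swapping fluoro for chloro in an SEM cell assay

A few compounds are considered here, and "the series" means these few. Any claim that something is new, unique, unknown or untested is made for them only; others in the source may bear on it.

Compound 1 `COc1cc(NC(=O)/C=C/c2cccc(OCc3ccccc3)c2)cc(OC)c1OC`: 8500 nM
Compound 2 `C=C(Br)C(=O)Nc1cccc(/C=C/C(=O)Nc2cccc3ccccc23)c1`: 830 nM
Compound 3 `C=C(Br)C(=O)Nc1cccc(/C=C/C(=O)Nc2ccc(F)cc2)c1`: 8400 nM

All three compounds were tested in a functional assay on SEM cells (Homo sapiens) for inhibition, read by MTT assay, with a stated time of 72 h; a higher number here means a weaker inhibitor, a lower number a stronger inhibitor. In this assay compound 3 gives 8400 nM, level with compound 1 at 8500 nM once the usual scatter of repeat measurements is allowed for. Compound 2 gives 830 nM, a clearly lower number than either, and so a stronger inhibitor.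

The next compound is compound 4 `C=C(Br)C(=O)Nc1cccc(/C=C/C(=O)Nc2ccc(Cl)cc2)c1`. Its change from compound 3 is chloro in place of fluoro on an aromatic carbon, para to a large group. Among the compounds with values here, no pair of measured compounds shows what a single change like this does, so any expectation here is loose. Because compound 2 reaches 830 nM, a lower number is possible among these close relatives, but a swap of one atom is expected to do far less. The expected change, a 1.5-fold lower number from compound 3 to compound 4 (0.18 log units; within the scatter), is a small fall that may not clear the scatter. For compound 4 the estimated value is 5500 nM, with an expected range of 2200 nM to 12000 nM.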

Compound 4, half-maximal inhibitory concentration: 1190 nM
For compound 4 the middle estimate is 4.6-fold (0.66 log units) above the measured one, and the stated range ends above it.
By their numbers in this assay, from the lowest: compounds 2 and 4 (each within the scatter of the next); then compounds 3 and 1 (each within the scatter of the next).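

In this assay, within the data shown here, chloro in place of fluoro gives a 7.1-fold lower number from compound 3 to compound 4 (0.85 log units; beyond the scatter), the first single change in this set that can be read directly. So this aromatic carbon, para to a large group, is not a silent spot: exchanging one halogen atom for another, with no change in ring, charge or hydrogen-bond donor and acceptor counts, moves the number beyond the usual scatter. No measurement at hand says why a swap of one atom has an effect of this size.

On these data alone, it remains open whether bromo, methyl, methoxy or an amine on the same carbon would extend this fall or reverse it. As far as these compounds go, it is also open whether chloro in place of fluoro would do the same on a different core.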